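Chloro to bromo on the para-substituted chalcone arm

The source may hold more compounds than are shown below. What is called first, only, known or untested is meant among the compounds shown, and "the series" means these compounds.

Compound 1 `Cc1c(C(=O)/C=C/c2ccc(Cl)cc2)[n+]([O-])c2ccccc2[n+]1[O-]` carries the shared core with a 4-chlorophenyl group. In an ADME assay on HPLF cells (Homo sapiens) for cytotoxicity, with a stated time of 48 h (on this read-out lower numbers stand for higher toxicity in this test and higher numbers for lower toxicity in this test), compound 1 gives 12000 nM, the second highest of the three numbers. Compound 2 `Cc1c(C(=O)/C=C/c2ccc(Cl)c(Cl)c2)[n+]([O-])c2ccccc2[n+]1[O-]` is nearest: in this assay compound 2 gives 5700 nM, and the step of a 2.1-fold lower number from compound 1 to compound 2 (0.32 log units; beyond the scatter). Compound 3 `COc1cc(/C=C/C(=O)c2c(C)[n+]([O-])c3ccccc3[n+]2[O-])cc(OC)c1OC` is furthest: in this assay compound 3 gives 33000 nM.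

Compound 4 `Cc1c(C(=O)/C=C/c2ccc(Br)cc2)[n+]([O-])c2ccccc2[n+]1[O-]` differs from compound 1 by bromo in place of chloro on an aromatic carbon. Going by the values given here, no measured step swaps one halogen for another; the only step at this aromatic carbon is a 2.1-fold lower number from compound 1 to compound 2 (0.32 log units; beyond the scatter), which adds a second chloro rather than exchanging the first. That step was modest, and a like-for-like halogen exchange is expected to move the number less still. For compound 4 in this assay the expected outcome is therefore no step beyond the scatter, with a 1.2-fold lower number from compound 1 to compound 4 (0.08 log units; within the scatter). The estimate for compound 4 in this assay is 10000 nM, with a range from 5000 nM to 24000 nM.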

Compound 4, half-maximal cytotoxic concentration: 26000 nM
Compound 4: the middle estimate sits 2.6-fold (0.41 log units) below what was measured, and the stated range ends below it.
By their numbers in this assay, from the lowest: compound 2; then compound 1; then compounds 4 and 3 (each within the scatter of the next).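

Working notes: at this aromatic carbon, the identity of the single halogen moves the number beyond the scatter in this assay, so chloro and bromo cannot be treated as interchangeable here (a 2.2-fold higher number from compound 1 to compound 4 (0.34 log units; beyond the scatter)). Going by these compounds alone, the direction is opposite to that of the only earlier step at this ring, where adding a second chloro lowered the number (a 2.1-fold lower number from compound 1 to compound 2 (0.32 log units; beyond the scatter)). The two changes combine in the comparison of the 3,4-dichlorophenyl and 4-bromophenyl arms, which gives the widest of the three steps (a 4.6-fold higher number from compound 2 to compound 4 (0.66 log units; beyond the scatter)).

Still open, from the compounds shown here alone, is where a fluoro or a dimethylamino group at this aromatic carbon would fall relative to chloro and bromo. Nothing available explains why the bromo exchange raises the number in this read-out.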